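From 4-fluorobenzyl to 2,4-dichlorobenzyl on the shared core

The compounds below may be only part of what the source reports. "The series", "measured", "known", "first", "only" and "open" are said of these compounds alone.

In a functional assay on HCT-116 cells (Homo sapiens) for cytotoxicity, read by MTT assay, with a stated time of 72 h (on this read-out lower numbers stand for stronger inhibition and higher numbers for weaker inhibition), compound 1 `N[C@H]1CC[C@H](Nc2c(C(=O)NCc3ccco3)nc(Br)c3cccnc23)CC1` reads > 10000 nM, which is a limit of the assay. For the measured compounds named here, compound 2 `N[C@H]1CC[C@H](Nc2c(C(=O)NCc3ccc(F)cc3)nc(Br)c3cccnc23)CC1` gives 7000 nM, the only actual number so far. Compound 3 `N[C@H]1CC[C@H](Nc2c(C(=O)NCc3ccc(Cl)cc3Cl)nc(Br)c3cccnc23)CC1` carries 2,4-dichlorophenyl in place of 4-fluorophenyl on a saturated chain carbon bound to an amide-type nitrogen. Going by the values given here, the one measured step at this place, an at least 1.4-fold lower number from compound 1 to compound 2 (0.15 log units; that floor lies within the scatter), has a floor within the scatter, so only a modest move toward lower numbers is expected. The expected step is a 1.4-fold lower number from compound 2 to compound 3 (0.15 log units; within the scatter). For compound 3 the estimated value is 5000 nM, within an expected range of 2000 nM to 10000 nM.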

Compound 3, half-maximal inhibitory concentration: 6000 nM
Beside the measured number, compound 3's estimate is 1.2-fold (0.08 log units) below it, and the stated range covers the measured number.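

In this assay, for the compounds shown here, the first step with numbers at both ends reads a 1.2-fold lower number from compound 2 to compound 3 (0.07 log units; within the scatter), so 2,4-dichlorophenyl and 4-fluorophenyl cannot be told apart at this place on the amide side chain. Against furan-2-yl, the reading is an at least 1.6-fold lower number from compound 1 to compound 3 (0.22 log units; that floor lies within the scatter). Compound 1 holds a limit and not a number, so that step has only a floor.

On these data alone, how far compound 1 truly lies from compound 3 stays open. So does whether an unsubstituted phenyl, a longer chain such as phenethyl, or a phenyl carrying an amine or a carboxylic acid would move the reading beyond the scatter.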